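The source may hold more compounds than are shown below. What is called first, only, known or untested is meant among the compounds shown, and "the series" means these compounds.

Measured compounds in a functional assay on U-87MG ATCC cells for antiproliferative activity against U-87 MG (Homo sapiens), read by MTT assay, with a stated time of 48 h; on this read-out higher numbers stand for weaker inhibition and lower numbers for stronger inhibition:
compound 1 `COc1cc(OC)c2c(=O)c(OCCCOc3ccccc3/C=C/C(=O)/C=C/c3cccc([N+](=O)[O-])c3)c(-c3cc(OC)c(OC)c(OC)c3)oc2c1` gives 7920 nM
compound 2 `COc1cc(OC)c2c(=O)c(OCCCCOc3ccc(/C=C/C(=O)/C=C/c4scnc4C)cc3)c(-c3cc(OC)c(OC)c(OC)c3)oc2c1` gives 58700 nM
compound 3 `COc1cc(OC)c2c(=O)c(OCCCCOc3ccccc3/C=C/C(=O)/C=C/c3ccco3)c(-c3cc(OC)c(OC)c(OC)c3)oc2c1` gives 10700 nM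

In this assay compound 3 stands second highest of the three numbers; compound 1 is its nearest neighbour and lies within the scatter, while compound 2 is the furthest, a higher number beyond the scatter. Compound 4 `COc1cc(OC)c2c(=O)c(OCCCCOc3ccccc3/C=C/C(=O)/C=C/c3ccc(Cl)cc3)c(-c3cc(OC)c(OC)c(OC)c3)oc2c1` differs from compound 3 by 4-chlorophenyl in place of furan-2-yl on a double-bonded chain carbon bound to a double-bonded chain carbon. Among the compounds with values here, no pair of measured compounds differs in one place, so no measured step shows the size of such a change; the expectation rests on compound 3 alone. Compound 4 is expected near 8000 nM, with a range from 3000 nM to 22000 nM. The estimated step of a 1.3-fold lower number from compound 3 to compound 4 (0.13 log units; within the scatter) is expected to stay within the scatter, with no clear direction.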

Compound 4, half-maximal inhibitory concentration: 21100 nM
Beside the measured number, compound 4's estimate is 2.6-fold (0.42 log units) below it, within the range that was stated.
By their numbers in this assay, from the lowest: compounds 1, 3 and 4 (each within the scatter of the next, the first and the last beyond it); then compound 2.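

In this assay 4-chlorophenyl in place of furan-2-yl gives a 2.0-fold higher number from compound 3 to compound 4 (0.29 log units; within the scatter). Within the data shown here, this is the first single-place comparison, and at this position it shows that exchanging a five-membered oxygen-containing aromatic ring for a chlorinated six-membered carbon ring does not separate the two compounds beyond the scatter. Nothing available bears on this result. Open, from the compounds shown here alone, is whether an amine or a carboxylic acid at this place would give a step beyond the scatter. Also open, going by these compounds, is whether a longer chain to the shared core would do so.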